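One Added Methyl on Compound 3

The source may hold more compounds than are shown below. What is called first, only, known or untested is meant among the compounds shown, and "the series" means these compounds.

In a functional assay on HepG2 cells (Homo sapiens) for inhibition, read by fluorescence and resazurin assay, with a stated time of 72 h (a lower number here means a stronger inhibitor, a higher number a weaker inhibitor), compound 1 `O=C(Nc1ccccc1)Nc1cccc(Nc2nccc(Nc3ccc4[nH]ncc4c3)n2)c1` reads 8100 nM and compound 2 `O=C(Nc1ccccc1)Nc1cccc(Nc2nccc(Nc3ccc4[nH]ccc4c3)n2)c1` reads 5000 nM while compound 3 `Cn1cc2ccc(Nc3ccnc(Nc4cccc(NC(=O)Nc5ccccc5)c4)n3)cc2n1` reads 12000 nM on the same scale. Compound 3 thus stands level with compound 1 within the scatter (a 1.5-fold higher number from compound 1 to compound 3 (0.17 log units; within the scatter)) and sits apart from compound 2 by a modest margin (a 2.4-fold higher number from compound 2 to compound 3 (0.38 log units; beyond the scatter)).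

Compound 4 `Cc1c2ccc(Nc3ccnc(Nc4cccc(NC(=O)Nc5ccccc5)c4)n3)cc2nn1C` keeps the frame of compound 3 and carries methyl in place of hydrogen on an aromatic carbon, turning 2-methyl-2H-indazol-6-yl into 2,3-dimethyl-2H-indazol-6-yl (methyl in place of hydrogen on an aromatic carbon). For the measured compounds named here, no measured pair shows this methyl alone. Going by the values given here, the only evidence comes from exchanges of the whole group on the nitrogen, and those steps stayed small. Two lie within the scatter (a 1.6-fold lower number from compound 1 to compound 2 (0.21 log units; within the scatter) and a 1.5-fold higher number from compound 1 to compound 3 (0.17 log units; within the scatter)) and the largest is modest (a 2.4-fold higher number from compound 2 to compound 3 (0.38 log units; beyond the scatter)). A single added methyl is a smaller alteration than any of these exchanges, and no step beyond the scatter is expected in this assay in either direction. The estimated change is a 1.2-fold lower number from compound 3 to compound 4 (0.08 log units; within the scatter) and it carries no firm direction. For compound 4 the expected value is 10000 nM with an estimated range (4500 nM to 22000 nM).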

Compound 4, half-maximal inhibitory concentration: 2400 nM
For compound 4 the middle estimate is 4.2-fold (0.62 log units) above the measured one; measured number outside the range, below it.
By their numbers in this assay, from the lowest: compound 4; then compounds 2, 1 and 3 (each within the scatter of the next, the first and the last beyond it).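

In this assay, for the compounds shown here, the methyl on the aromatic carbon of the five-membered aromatic ring, next to the ring nitrogen and next to the ring atom that bears a methyl group, gives a 5.0-fold lower number from compound 3 to compound 4 (0.70 log units; beyond the scatter), so this position responds to a change of a single heavy atom, and this step is larger than any step among the earlier compounds. The 2,3-dimethyl-2H-indazol-6-yl group also separates compound 4 from the other two groups on the nitrogen, with a 2.1-fold lower number from compound 2 to compound 4 (0.32 log units; beyond the scatter) and a 3.4-fold lower number from compound 1 to compound 4 (0.53 log units; beyond the scatter), which makes compound 4 the most potent of the four in this assay, whereas the earlier exchanges had moved the number little. Nothing available here explains how this methyl lowers the number.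

The compounds shown carry only hydrogen or methyl on this carbon, so it remains open whether an ethyl, a methoxy or an amine there would lower the number further, keep it level or raise it. As far as these compounds go, it is also open whether the methyl would have a similar effect on the 1H-indazol-5-yl group of compound 1, which lacks the methyl on the ring nitrogen.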